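Anilino for Hydroxy on a Weakly Inhibiting Acid

The compounds below may be only part of what the source reports. "The series", "measured", "known", "first", "only" and "open" are said of these compounds alone.

In a functional assay on KB cells (Homo sapiens) for inhibition, read by MTT assay, with a stated time of 24 h, tested at 10 ug/mL (a lower number here means less inhibition of growth, a higher number more inhibition of growth at the concentration tested), compound 1 (`O=C(O)CCCCC(CCSC(=O)c1ccccc1)SC(=O)c1ccccc1`) gives 2.68% of inhibition, a small reading. Among the measured compounds shown here, the only other measured compound, compound 2 (`O=C(CCCCC(S)CCS)Nc1ccccc1`), gives 8.62% in this assay and these two numbers lie within the scatter of each other, so compound 1 stands level with compound 2 on the available data.

Compound 3 (`O=C(CCCCC(CCSC(=O)c1ccccc1)SC(=O)c1ccccc1)Nc1ccccc1`) has not yet been measured. It differs from compound 1 in a single place, with anilino in place of hydroxy on a carbonyl carbon, which turns carboxy into phenylcarbamoyl (anilino in place of hydroxy on a carbonyl carbon). For the measured compounds named here, no measured pair of compounds isolates a change of this kind, so the size of the step can only be judged loosely. With compound 1 at 2.68% and compound 2 at 8.62% both readings are small, and no shift beyond the scatter is expected. The estimate for the step (a number 5.3 percentage points higher from compound 1 to compound 3 (within the scatter)) is a modest rise. In this assay the expected inhibition for compound 3 is 8% with an estimated range of 0% to 25% around it.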

Compound 3, percent growth inhibition at one concentration: 2.67%
For compound 3 the middle estimate is 5.3 percentage points above the measured one, and the stated range covers the measured number.
By their numbers in this assay, from the lowest: compounds 3, 1 and 2 (each within the scatter of the next).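

Anilino in place of hydroxy on a carbonyl carbon gives a number 0 percentage points lower from compound 1 to compound 3 (within the scatter) in this assay, the first measured pair to isolate this change. At this place on the chain, carboxy can therefore be exchanged for phenylcarbamoyl, bringing in a six-membered aromatic ring of carbon only, without any shift that can be told from the scatter. No supporting measurement accompanies the result, and the absence of a shift remains unexplained.

The pair covers only one replacement for hydroxy, and both readings are small, so it cannot tell whether this place would matter on a compound with greater inhibition of growth. It also leaves open whether a methyl ester, a simple alkylamino group such as methylamino, or a chlorine atom on the phenyl ring of the anilino group would move the reading beyond the scatter, or whether a longer chain between the carbonyl carbon and the rest of the core would do so.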